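This account rests on a few compounds, and the source may have more. Where it says the series, first, only, none or still open, it means among the compounds named here.

Measured in a functional assay on Gurav cells (Homo sapiens) for inhibition, read by sulforhodamine B assay; a lower number here means a stronger inhibitor of growth, a higher number a weaker inhibitor of growth:
- Compound 1 `Cc1ccc2[nH]c(-c3ccc(-c4ccc(-c5cccc(Cl)c5)cc4)cc3)nc2c1`: 2120 nM
- Compound 2 `Fc1ccc(-c2ccc(-c3ccc(-c4nc5ccccc5[nH]4)cc3)cc2)cc1`: 100000 nM

Compound 2 has the higher number of the pair, and the gap to compound 1 lies well beyond the usual scatter, so compound 2 is the weaker inhibitor of growth. Compound 3 `Cc1ccc2[nH]c(-c3ccc(-c4ccc(-c5ccc(F)cc5)cc4)cc3)nc2c1` differs from compound 2 in one place, with methyl in place of hydrogen on an aromatic carbon.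

Among the compounds with values here, no measured pair shows this change alone. The only hint is that the same methyl group is present in compound 1 at 2120 nM, though that compound also differs from compound 2 elsewhere. A step to a lower number in this assay, beyond the scatter, is therefore expected, but its size is uncertain. The expected step is a 17-fold lower number from compound 2 to compound 3 (1.22 log units; beyond the scatter). For compound 3 the estimated value is 6000 nM, with an expected range of 1500 nM to 50000 nM.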

Compound 3, concentration for 50% growth inhibition: 16500 nM
Beside the measured number, compound 3's estimate is 2.8-fold (0.44 log units) below it; the range from low to high includes it.
By their numbers in this assay, from the lowest: compound 1; then compound 3; then compound 2.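

In this assay the methyl on an aromatic carbon of the fused system now has a step of its own: a 6.1-fold lower number from compound 2 to compound 3 (0.78 log units; beyond the scatter) shows that this one added carbon is enough to move the number beyond the scatter. The methyl alone does not bring the number down to that of compound 1, since 4-fluorophenyl in place of 3-chlorophenyl gives a 7.8-fold higher number from compound 1 to compound 3 (0.89 log units; beyond the scatter) with the methyl present on both sides of the comparison. Nothing at hand explains why either change has the effect it does.

The compounds shown leave open whether a larger group at this carbon, such as ethyl or methoxy, would lower the number further. They also leave open how an amine in place of the fluorine of the 4-fluorophenyl group would compare.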